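Working notes: replacing dimethylamino in compound 2

A few compounds are considered here, and "the series" means these few. Any claim that something is new, unique, unknown or untested is made for them only; others in the source may bear on it.

Values in a functional assay on the whole organism (strain Sprague-Dawley) for inhibition, with Rattus norvegicus as the target, with a stated time of 10 min (a lower number here means that less compound is needed, a higher number that more compound is needed for the effect), so far:
- compound 1 (`CCOC(=O)c1cnc(-c2cc(Cl)ccc2OCC)[nH]c1=O`) gives (0.5 mg/kg)
- compound 2 (`CCOC(=O)c1cnc(-c2cc(N(C)C)ccc2OCC)[nH]c1=O`) gives ("not determined" (no result reported))

Awaiting measurement: compound 3 (`CCOC(=O)C(=O)Nc1ccc(OCC)c(-c2ncc(C(=O)OCC)c(=O)[nH]2)c1`).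

Compound 2 has no single number, so it gives no starting point for a step. The step ((ethoxycarbonyl)carbonyl)amino in place of dimethylamino on an aromatic carbon puts ((ethoxycarbonyl)carbonyl)amino in place of dimethylamino on an aromatic carbon. No size or direction of step from compound 2 can be stated in this assay. Among the compounds with values here, the only number is that of compound 1 (0.5 mg/kg), and no departure beyond the scatter from it is expected. Compound 3 is expected at 0.7 mg/kg (estimated range 0.15 mg/kg to 3.5 mg/kg).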

Compound 3, dose for 50% inhibition: 5 mg/kg
Estimate against measurement, compound 3: 7.1-fold (0.85 log units) below; measured number above the stated range.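

This position does not tolerate every replacement of chloro equally in this assay: ((ethoxycarbonyl)carbonyl)amino in place of chloro gives a 10-fold higher number from compound 1 to compound 3 (1.00 log units; beyond the scatter) on the core of compound 1. Within the data shown here, the step from compound 2 cannot be read, so chloro is the only reference for this change. No measurement on these compounds accounts for the step. On these data alone, whether the higher number goes with the amino nitrogen or with the ethoxycarbonyl end of the entering group stays open. An acetylamino group or a free carboxylic acid at this place would separate the two.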